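Chloro to nitro on the side arm of compound 2

The source may report more compounds than this note shows. Statements on the series, on what has been measured and on what is new or still open speak of the compounds shown alone.

Compound 2 `O=c1ccoc2cc(OCc3cn(Cc4cccc(Cl)c4)nn3)ccc12` is one of two compounds tested in a functional assay on SGC-7901 cells (Homo sapiens) for cytotoxicity, read by MTT assay, with a stated time of 48 h; on this read-out higher numbers stand for weaker inhibition and lower numbers for stronger inhibition. In this assay compound 2 gives only a limit, > 100000 nM. Its companion compound 1 `O=c1ccoc2cc(OCc3cn(Cc4ccc(Cl)cc4)nn3)ccc12` also reaches only a limit in this assay, > 100000 nM. The step that the two limits leave unreadable from compound 1 to compound 2 cannot be read because both values sit at the limit of > 100000 nM in this assay, at which 2 of the 2 values shown sit.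

Compound 3 `O=c1ccoc2cc(OCc3cn(Cc4cccc([N+](=O)[O-])c4)nn3)ccc12` differs from compound 2 by nitro in place of chloro on an aromatic carbon. For the measured compounds named here, no measured step bears directly on this exchange, and the single step available, from compound 1 to compound 2, is itself unreadable. Both measured compounds sit at the limit of > 100000 nM in this assay, at which 2 of the 2 values shown sit. For compound 3 in this assay the expected result is another value at or near that limit, so the step of a number no higher from compound 2 to compound 3 (the limit leaves the size open) is expected to be none beyond the scatter. Compound 3 is estimated at 100000 nM, with a range from 30000 nM to 500000 nM.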

Compound 3, half-maximal inhibitory concentration: > 100000 nM
Compound 3 gave a limit, no number (the forecaster's own chance of this, stated with the estimate: 75%); the middle value lies on the limit itself.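

In this assay compound 3 also gives only a limit (> 100000 nM). For the compounds shown here, no step among compound 1, compound 2 and compound 3 can therefore be read: (the limit of > 100000 nM in this assay, at which 3 of the 3 values shown sit). In this assay the compounds shown leave open whether any change on the side arm would give a readable value.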